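A few compounds are considered here, and "the series" means these few. Any claim that something is new, unique, unknown or untested is made for them only; others in the source may bear on it.

Measured so far in a physicochemical assay for lipophilicity, using potentiometric titration, at pH 7.4; on this read-out lower numbers stand for lower lipophilicity and higher numbers for higher lipophilicity:

- Compound 1 `Fc1ccc(-c2nc(-c3ccc(Br)cc3)no2)cc1F`: 3.91
- Compound 2 `COc1cccc(-c2noc(-c3ccc(F)c(F)c3)n2)c1`: 3.91

Compound 1 gives 3.91 and compound 2 gives 3.91, so the two stand level, within the scatter of repeated measurements. Neither compound can therefore be placed above the other.

Compound 3 `CC(C)(C)c1ccc(-c2noc(-c3ccc(F)c(F)c3)n2)cc1` has not yet been measured. It keeps the core of compound 1 and differs in one place, with tert-butyl in place of bromo on an aromatic carbon, para to a large group (tert-butyl in place of bromo on an aromatic carbon).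

Within the data shown here, no measured pair shows a change of this kind, so the data offer no direct guide to its size. The expectation rests on the structural change alone: a rise in this assay, moderate in size but beyond the scatter. The expected step is a number 0.69 log units higher from compound 1 to compound 3 (beyond the scatter). Compound 3 is estimated at 4.6, with an expected range of 4.1 to 5.1.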

Compound 3, distribution coefficient: 3.92
Beside the measured number, compound 3's estimate is 0.68 log units above it; measured number outside the range, below it.
By their numbers in this assay, from the lowest: compounds 1, 2 and 3 (each within the scatter of the next).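

Putting tert-butyl in place of bromo on an aromatic carbon, para to a large group, gives a number 0.01 log units higher from compound 1 to compound 3 (within the scatter) in this assay. Among these compounds, this is the first direct reading of a change at this position, and it shows that this assay does not separate the two groups here, even though tert-butyl brings 4 heavy atoms where bromo has 1. No separate measurement is available to explain why these two groups read alike.

As far as these compounds go, it remains open whether an amine, a carboxylic acid or a longer carbon chain at this same position would shift the number beyond the scatter. From the compounds shown here alone, it is also open whether bromo and tert-butyl would read alike on a core other than that of compound 1.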